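Swapping Methoxy for Fluoro: A Step Without Precedent

The compounds below may be only part of what the source reports. "The series", "measured", "known", "first", "only" and "open" are said of these compounds alone.

Among the compounds with values here, compound 1 `COc1ccc(-c2ncnn2-c2cc(OC)c(OC)c(OC)c2)cc1` is the only compound here with a definite number: in a functional assay on HeLa cells (Homo sapiens) for antiproliferative activity, read by MTT assay, with a stated time of 72 h (on this read-out higher numbers stand for weaker inhibition and lower numbers for stronger inhibition), compound 1 gives 280 nM. Compound 2 `COc1ccc(-n2ncnc2-c2cc(OC)c(OC)c(OC)c2)cc1` reaches only the limit of the assay, > 10000 nM. Compound 3 `COc1cc(-c2ncnn2-c2ccc(Cl)c(Cl)c2)cc(OC)c1OC` likewise stops at the assay limit, > 10000 nM. The change from compound 2 to compound 3, 3,4-dichlorophenyl in place of 4-methoxyphenyl on an aromatic nitrogen, is a step that the two limits leave unreadable from compound 2 to compound 3, since each of the two sits at the limit of > 10000 nM in this assay, at which 2 of the 3 values shown sit. Compound 4 `COc1cc(-n2ncnc2-c2ccc(F)cc2)cc(OC)c1OC` differs from compound 1 by fluoro in place of methoxy on an aromatic carbon. Within the data shown here, no measured step covers a methoxy-to-fluoro exchange, so the expectation rests on compound 1 alone. Compound 4 is therefore estimated at 500 nM, between 150 nM and 4000 nM. That estimate means an expected step of a 1.8-fold higher number from compound 1 to compound 4 (0.25 log units; within the scatter), within the usual scatter.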

Compound 4, half-maximal inhibitory concentration: > 10000 nM
Compound 4: no number, only a limit (the forecaster's own chance of this, stated with the estimate: 20%); middle value at least 20-fold (1.30 log units) from the limit.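

In this assay, replacing methoxy with fluoro on this ring gives an at least 35-fold higher number from compound 1 to compound 4 (1.55 log units; beyond the scatter), so a change of a single small group here is enough to take the compound from a measurable value to the assay limit. This is the first readable step in the series, and it makes the methoxy of compound 1 the one group shown to matter at this position. Its true size stays unknown, since the value of compound 4 is only a limit: the limit of > 10000 nM in this assay, at which 3 of the 4 values shown sit.

From the compounds shown here alone, whether an ethoxy, a hydroxyl or an amine in this place would retain activity remains open.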